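Methoxy to chloro on compound 3: an estimate for compound 4

This account rests on a few compounds, and the source may have more. Where it says the series, first, only, none or still open, it means among the compounds named here.

Of the compounds shown here, three have so far been measured in a functional assay on cells (Cancer cell lines, Homo sapiens) for cytotoxicity, read by sulforhodamine B assay, with a stated time of 48 h; a lower number here means a stronger inhibitor of growth, a higher number a weaker inhibitor of growth. Compound 1 `O=C1N=C(N2N=C(c3ccccc3)CC2c2ccccc2O)S/C1=C1/C(=O)Nc2ccccc21` gives 2410 nM. Compound 2 `COc1ccc(C2=NN(C3=NC(=O)/C(=C4\C(=O)Nc5ccc(Br)cc54)S3)C(c3ccc(OC)cc3)C2)cc1` gives 240 nM, and compound 3 `COc1ccc(C2=NN(C3=NC(=O)/C(=C4\C(=O)Nc5ccc(Cl)cc54)S3)C(c3ccc(OC)cc3)C2)cc1` gives 230 nM. Among the compounds with values here, compound 3 shows the lowest of the three numbers, though its nearest neighbour, compound 2, lies within the scatter, and the only measured step, a 1.0-fold lower number from compound 2 to compound 3 (0.02 log units; within the scatter), is likewise within the scatter. Compound 1 stands far off, beyond the scatter.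

Compound 4 `COc1ccc(C2=NN(C3=NC(=O)/C(=C4\C(=O)Nc5ccc(Cl)cc54)S3)C(c3ccc(Cl)cc3)C2)cc1` differs from compound 3 in one place: chloro in place of methoxy on an aromatic carbon. Within the data shown here, no measured step concerns a change of this kind; the single measured step is a swap between two halogens on the shared core and did not move the number beyond the scatter. Nothing in the measurements therefore points to a direction for the new change, and no step beyond the scatter is expected. Compound 4 is expected to give about 250 nM in this assay, between 100 nM and 650 nM. This estimate means an expected step of a 1.1-fold higher number from compound 3 to compound 4 (0.04 log units; within the scatter).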

Compound 4, concentration for 50% growth inhibition: 270 nM
Compound 4: the middle estimate sits 1.1-fold (0.03 log units) below what was measured; low and high end bracket the measured number.
By their numbers in this assay, from the lowest: compounds 3, 2 and 4 (each within the scatter of the next); then compound 1.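

In this assay, exchanging the 4-methoxyphenyl of compound 3 for the 4-chlorophenyl of compound 4 gives a 1.2-fold higher number from compound 3 to compound 4 (0.07 log units; within the scatter), so at this place, para to a large group, the two numbers cannot be told apart. Within the data shown here, the only earlier step was a swap between two halogens at a different place on the shared core, so this is the first reading of a change on this ring, and here a methoxy and a chloro read alike. No outside data are at hand to explain this result.

Two groups say little about how much change this place allows, and an amine, a carboxylic acid or a longer chain such as butoxy could read quite differently. Going by these compounds, it also stays open whether the same match between methoxy and chloro would hold with bromo on the shared core.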